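This account rests on a few compounds, and the source may have more. Where it says the series, first, only, none or still open, it means among the compounds named here.

Measured so far in an assay on isolated protein for displacement of a labelled ligand from 5-hydroxytryptamine receptor 6 (Homo sapiens), read by scintillation counting, with a stated time of 1 h; a higher number here means a weaker inhibitor, a lower number a stronger inhibitor:

compound 1 `COc1ccc2c(ccn2S(=O)(=O)c2ccccc2)c1` gives 127 nM
compound 2 `CN1CCN(c2cn(S(=O)(=O)c3ccccc3)c3ccccc23)CC1` gives 4 nM
compound 3 `CN(C)c1cn(S(=O)(=O)c2ccccc2)c2ccccc12` gives 474 nM

Compound 2 stands lowest of the three numbers; compound 1 lies well beyond the scatter above it, and compound 3 further still. The next compound, compound 4 `O=S(=O)(c1ccccc1)n1cc(-c2ccccc2)c2ccccc21`, differs from compound 2 in one place: phenyl in place of 4-methylpiperazin-1-yl on an aromatic carbon.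

Among the compounds with values here, the one measured step that bears on this is a 120-fold higher number from compound 2 to compound 3 (2.07 log units; beyond the scatter), where the 4-methylpiperazin-1-yl group was exchanged for a smaller nitrogen group at the same aromatic carbon and the number rose sharply. Within the data shown here, in compound 4 the same group is exchanged for phenyl, which carries none of the counted acceptors; nothing among the measured compounds tests phenyl at that carbon directly. Among the measured compounds shown here, the expectation is therefore a large rise from compound 2 to compound 4, of roughly the size seen in the step from compound 2 to compound 3, with wide uncertainty because compound 3 474 nM is the only guide. Compound 4 is estimated at 300 nM (range 50 nM to 2000 nM), which means an expected step of a 75-fold higher number from compound 2 to compound 4 (1.88 log units; beyond the scatter).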

Compound 4, inhibition constant: 146 nM
The estimate for compound 4 lay 2.1-fold (0.31 log units) above the measured number; measured number inside the range.
By their numbers in this assay, from the lowest: compound 2; then compounds 1 and 4 (each within the scatter of the next); then compound 3.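

Moving to phenyl gives a 37-fold higher number from compound 2 to compound 4 (1.56 log units; beyond the scatter), so a second, structurally unrelated replacement at this aromatic carbon also falls far short of 4-methylpiperazin-1-yl. The loss is therefore not specific to dimethylamino, although phenyl, which carries no hydrogen-bond acceptors, still gives a 3.2-fold lower number from compound 3 to compound 4 (0.51 log units; beyond the scatter), so among these three groups the number does not follow the acceptor count in any simple way. No measurement shown here gives a reason for either step.

On these data alone, it remains open which part of 4-methylpiperazin-1-yl matters: piperazin-1-yl without the methyl, morpholine and piperidine at this carbon would begin to separate the ring from its second nitrogen. A longer chain ending in dimethylamino would test whether the ring itself is needed at all.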